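Amide aryl exchange in a dopamine receptor agonist series

The compounds below may be only part of what the source reports. "The series", "measured", "known", "first", "only" and "open" are said of these compounds alone.

Measured so far:
compound 1 `c1ccc(C2CCN(Cc3nc4ccccc4[nH]3)CC2)nc1` — 12 nM
compound 2 `O=C(CN1CCC(c2cccc[n+]2[O-])CC1)Nc1ccc(F)cc1F` — 103 nM
compound 3 `O=C(NCN1CCC(c2cccc[n+]2[O-])CC1)c1ccc(F)c(Cl)c1` — 63 nM

In a functional assay on HEK293 cells for agonist activity at D(4) dopamine receptor (Homo sapiens), read by FLIPR (on this read-out higher numbers stand for an effect only at larger amounts of compound and lower numbers for an effect already at smaller amounts), compound 2 gives the highest of the three numbers. The gap to compound 3 lies within the scatter, so the two are not separated by this measurement. Compound 1, with its different core, stands beyond the scatter below compound 2.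

Compound 4 `CSc1cccc(NC(=O)CN2CCC(c3cccc[n+]3[O-])CC2)c1` has not yet been measured. Relative to compound 2 it carries 3-(methylsulfanyl)phenyl in place of 2,4-difluorophenyl on an amide-type nitrogen. The 2,4-difluorophenyl leaves and the 3-(methylsulfanyl)phenyl enters on the amide-type nitrogen whose other neighbour is the carbonyl carbon; the entering group brings one hydrogen-bond acceptor where the leaving group had none.

Among the measured compounds shown here, no measured pair shows this exchange, so nothing in the data sets its size. The expectation is a step of a 1.2-fold higher number from compound 2 to compound 4 (0.07 log units; within the scatter) of no clear direction, most likely within the scatter. Compound 4 is estimated at 120 nM in this assay, with a range from 40 nM to 400 nM.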

Compound 4, half-maximal effective concentration: 100 nM
Compound 4: middle estimate off by 1.2-fold (0.08 log units), on the high side; low and high end bracket the measured number.
By their numbers in this assay, from the lowest: compound 1; then compounds 3, 4 and 2 (each within the scatter of the next).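

Among the compounds shown here, exchanging 2,4-difluorophenyl for 3-(methylsulfanyl)phenyl on the amide-type nitrogen gives, in this assay, a 1.0-fold lower number from compound 2 to compound 4 (0.01 log units; within the scatter) and is the only step so far that can be read at this position. In this single pair, the position accepts an aryl group with a different substitution and one hydrogen-bond acceptor, with no separation between the two compounds on this read-out. Nothing available explains why the two aryl groups read alike.

Still open, going by these compounds, is whether this tolerance extends beyond these two substituted phenyl groups, for example to an unsubstituted phenyl, a cyclohexyl group or a phenyl carrying a carboxylic acid or an amine. Also open, on these data alone, is whether a longer chain between the amide-type nitrogen and the aryl group would leave the number within the scatter of compound 2.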